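A few compounds are considered here, and "the series" means these few. Any claim that something is new, unique, unknown or untested is made for them only; others in the source may bear on it.

Working notes on the series, oral exposure in rat.

Compound 1 `Cc1cn2c(-c3cn[nH]c3)cnc2c(Nc2cc(Cc3ccccn3)ns2)n1` is the reference point. In an ADME assay on the whole organism for pharmacokinetics, with Rattus norvegicus as the target, with a stated time of 6 h, at a dose of 10 mg/kg by the oral route (a higher number here means more compound in the circulation at the dose given, a lower number less compound in the circulation), compound 1 gives 6880 ng.h/mL, the higher of the two numbers in hand. For the measured compounds named here, its one measured neighbour, compound 2 `Cc1cn2c(-c3cn[nH]c3)cnc2c(Nc2cc(Cc3ncccc3C)ns2)n1`, carries methyl in place of hydrogen on an aromatic carbon and gives 644 ng.h/mL in this assay, the step being an 11-fold lower number from compound 1 to compound 2 (1.03 log units; beyond the scatter).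

Compound 3 `Cc1cn2c(-c3cn[nH]c3)cnc2c(Nc2cc(C(c3ccccn3)N3CCCCC3)ns2)n1` differs from compound 1 by piperidin-1-yl in place of hydrogen on a saturated chain carbon bound to two aromatic carbons. Going by the values given here, no measured step covers a change at this saturated chain carbon; the step from compound 1 to compound 2 only shows that this assay is sensitive to a small change on the pyridine side of the molecule, with compound 2 falling well beyond the scatter. For compound 3 a lower number than compound 1 is therefore expected, estimated as a 4.6-fold lower number from compound 1 to compound 3 (0.66 log units; beyond the scatter). The estimate for compound 3 in this assay is 1500 ng.h/mL, in a range from 300 ng.h/mL to 6000 ng.h/mL.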

Compound 3, area under the concentration-time curve: 99 ng.h/mL
Beside the measured number, compound 3's estimate is 15-fold (1.18 log units) above it, outside the stated range (below it).
By their numbers in this assay, from the lowest: compound 3; then compound 2; then compound 1.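

In this assay the saturated chain carbon bound to two aromatic carbons is now shown to tolerate substitution poorly: piperidin-1-yl in place of hydrogen there gives a 69-fold lower number from compound 1 to compound 3 (1.84 log units; beyond the scatter), the first measured step at this carbon. The step runs in the same direction as methyl in place of hydrogen on an aromatic carbon, an 11-fold lower number from compound 1 to compound 2 (1.03 log units; beyond the scatter), and compound 1 stays the highest of the three numbers. Nothing in hand bears on what lies behind the drop in compound 3.

The compounds shown leave open whether the drop belongs to piperidin-1-yl in particular or follows any group at this carbon. A single methyl, a hydroxyl, dimethylamino or morpholin-4-yl at the same carbon would separate these two readings.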